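A few compounds are considered here, and "the series" means these few. Any claim that something is new, unique, unknown or untested is made for them only; others in the source may bear on it.

Measured in a functional assay on Caco-2 cells (Homo sapiens) for antiproliferative activity, read by sulforhodamine B assay, with a stated time of 48 h; on this read-out higher numbers stand for weaker inhibition and lower numbers for stronger inhibition:
compound 1 `COc1cc(NC(C)CCCNC(=O)CN2C(=O)[C@H](C)NC2(C)C)c2ncccc2c1`: 58000 nM
compound 2 `COc1cc(NC(C)CCCNC(=O)CN2C(=O)[C@H](C)NC23CCCCC3)c2ncccc2c1`: 74700 nM
compound 3 `COc1cc(NC(C)CCCNC(=O)CNC(=O)[C@H](C)N)c2ncccc2c1`: only a limit, > 100000 nM

Compound 3 therefore sits at the limit of > 100000 nM in this assay, at which 1 of the 3 values shown sits, and gives no number in this assay. Compound 4 `COc1cc(NC(C)CCCNC(=O)C2CCCN2C(=O)[C@@H](C)N)c2ncccc2c1` differs from it by 1-((1-aminoethyl)carbonyl)pyrrolidin-2-yl in place of (((1-aminoethyl)carbonyl)amino)methyl on a carbonyl carbon. Among the measured compounds shown here, the only measured step touching that part of the chain is an at least 1.7-fold higher number from compound 1 to compound 3 (0.23 log units; that floor lies within the scatter), a change that moved the value no further than the scatter at its floor. For the measured compounds named here, no measured step closes a chain into a five-membered ring, so the change from compound 3 to compound 4 has no direct precedent here; all three values are weak, and no shift beyond the scatter is expected in this assay. Compound 4 is expected at 90000 nM, between 40000 nM and 200000 nM. The expected step is an at least 1.1-fold lower number from compound 3 to compound 4 (0.04 log units; that floor lies within the scatter).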

Compound 4, half-maximal inhibitory concentration: 64000 nM
Beside the measured number, compound 4's estimate is 1.4-fold (0.15 log units) above it; the range from low to high includes it.
By their numbers in this assay, from the lowest: compounds 1, 4 and 2 (each within the scatter of the next). At a limit, above all of these: compound 3.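

Compound 3 stays a limit and not a number: the limit of > 100000 nM in this assay, at which 1 of the 4 values shown sits.

In this assay, 1-((1-aminoethyl)carbonyl)pyrrolidin-2-yl on the carbonyl carbon gives a measurable value, with an at least 1.5-fold lower number from compound 3 to compound 4 (0.19 log units; that floor lies within the scatter). Set against (2,2,4-trimethyl-5-oxoimidazolidin-1-yl)methyl, the same group gives a 1.1-fold higher number from compound 1 to compound 4 (0.04 log units; within the scatter), so these two groups cannot be told apart on this read-out.

Going by these compounds, it remains open whether any group at this place moves the value beyond the scatter. A piperidine in place of the pyrrolidine, or a carboxylic acid in place of the amine, would test this.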